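Working notes: from compound 2 to compound 3

A few compounds are considered here, and "the series" means these few. Any claim that something is new, unique, unknown or untested is made for them only; others in the source may bear on it.

Measured in a functional assay on MIA PaCa-2 cells (Homo sapiens) for inhibition, read by MTT assay, with a stated time of 48 h, tested at 10 uM; a higher number here means more inhibition of growth at the concentration tested, a lower number less inhibition of growth:
- compound 1 `Cc1cc(=O)c2c(O)c(CN3CCN(C(=O)OC(C)(C)C)CC3)c(O)c([C@H]3CCN(C)C[C@H]3O)c2o1`: 6%
- compound 2 `Cc1oc2c([C@H]3CCN(C)C[C@H]3O)c(O)cc(O)c2c(=O)c1C(O)c1cccc(Cl)c1`: 2%

In this assay, compound 2 gives 2% and compound 1 gives 6%, so the two values lie within the usual scatter of each other. Compound 3 `Cc1oc2c([C@H]3CCN(C)C[C@H]3O)c(O)cc(O)c2c(=O)c1C(O)c1c(F)cccc1Cl` carries 2-chloro-6-fluorophenyl in place of 3-chlorophenyl on a saturated chain carbon bound to an aromatic carbon and an oxygen on a saturated carbon. Among the compounds with values here, no measured pair shows the size of such a change. Starting from compound 2 at 2%, no step beyond the scatter is expected. The expected step is a number 3 percentage points higher from compound 2 to compound 3 (within the scatter). The estimate for compound 3 is 5%, with an expected range of 0% to 16%.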

Compound 3, percent growth inhibition at one concentration: 41%
Beside the measured number, compound 3's estimate is 36 percentage points below it; the whole stated range lies below it.
By their numbers in this assay, from the lowest: compounds 2 and 1 (each within the scatter of the next); then compound 3.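

In this assay, a single change at the saturated chain carbon bound to an aromatic carbon and an oxygen gives a number 39 percentage points higher from compound 2 to compound 3 (beyond the scatter) with the rest of the structure held constant. Within the data shown here, this is the first step to lie beyond the scatter, so the substitution pattern of the phenyl ring at this position matters in this assay. Nothing available accounts for a step of this size.

The compounds shown leave open whether the step follows from the added fluorine or from the different chlorine placement. From the compounds shown here alone, whether 2-chlorophenyl, 2,6-dichlorophenyl or 2,6-difluorophenyl would behave like 2-chloro-6-fluorophenyl also remains open.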